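The source may report more compounds than this note shows. Statements on the series, on what has been measured and on what is new or still open speak of the compounds shown alone.

Compounds sharing one core have been tested in a functional assay on SW-620 cells (Homo sapiens) for cytotoxicity, read by sulforhodamine B assay, with a stated time of 48 h; a higher number here means a weaker inhibitor, a lower number a stronger inhibitor. Compound 1 `C[C@H]1CC[C@@H]2[C@@H](OC(=O)[C@]23CC(c2c(Cl)cccc2Cl)=NO3)[C@]2(C)C(=O)C=C[C@@]12O`, which carries 2,6-dichlorophenyl, gives 43000 nM. Compound 2 `COc1ccc(C2=NO[C@]3(C2)C(=O)O[C@@H]2[C@H]3CC[C@H](C)[C@]3(O)C=CC(=O)[C@@]23C)cc1`, which carries 4-methoxyphenyl, gives 41000 nM. Compound 3 `C[C@H]1CC[C@@H]2[C@@H](OC(=O)[C@]23CC(c2ccc(Cl)cc2)=NO3)[C@]2(C)C(=O)C=C[C@@]12O`, which carries 4-chlorophenyl, gives 51000 nM. These numbers lie within the usual scatter of repeated measurements, so compound 3 cannot be separated from the other two.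

Compound 4 `C[C@H]1CC[C@@H]2[C@@H](OC(=O)[C@]23CC(c2ccccc2Br)=NO3)[C@]2(C)C(=O)C=C[C@@]12O` is still unmeasured. It has 2-bromophenyl in place of 4-chlorophenyl on a carbon with a double bond to nitrogen.

Going by the values given here, three measured steps bear on this swap. Exchanging 2,6-dichlorophenyl for 4-chlorophenyl gives a 1.2-fold higher number from compound 1 to compound 3 (0.07 log units; within the scatter). Exchanging 2,6-dichlorophenyl for 4-methoxyphenyl gives a 1.0-fold lower number from compound 1 to compound 2 (0.02 log units; within the scatter). Putting chloro in place of methoxy gives a 1.2-fold higher number from compound 2 to compound 3 (0.09 log units; within the scatter). All three stay within the scatter, so the aromatic group has so far made no measurable difference in this assay. Among the compounds with values here, no tested compound carries bromine, so that element remains untried here.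

No step beyond the scatter is therefore expected, in either direction. The expected step is a 1.2-fold lower number from compound 3 to compound 4 (0.08 log units; within the scatter). For compound 4 the estimated value is 42000 nM, with an expected range from 20000 nM to 85000 nM.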

Compound 4, half-maximal inhibitory concentration: 44000 nM
Beside the measured number, compound 4's estimate is 1.0-fold (0.02 log units) below it; measured number inside the range.
By their numbers in this assay, from the lowest: compounds 2, 1, 4 and 3 (each within the scatter of the next).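

Bromine now joins the aromatic groups tested at this position, and placing 2-bromophenyl in place of 4-chlorophenyl gives a 1.2-fold lower number from compound 3 to compound 4 (0.06 log units; within the scatter) in this assay with both the halogen and its ring position changed in a single swap. The other two exchanges tell the same story: 2-bromophenyl in place of 4-methoxyphenyl gives a 1.1-fold higher number from compound 2 to compound 4 (0.03 log units; within the scatter) and 2-bromophenyl in place of 2,6-dichlorophenyl gives a 1.0-fold higher number from compound 1 to compound 4 (0.01 log units; within the scatter) so all four substituted phenyl groups remain indistinguishable here, now including one with bromine. The data shown offer no explanation for this lack of separation.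

From the compounds shown here alone, every group tested on this carbon so far is a substituted phenyl ring, so it remains open whether an amine, a carboxylic acid or a longer alkyl chain in that place would move the number beyond the scatter. Going by these compounds, it is also open whether changes elsewhere on the shared core, such as replacing the hydroxyl group with a methoxy group, would shift the reading when the phenyl groups do not.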